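A thiazole sulfonamide with a fluoropyridine in place of a pyrazole

The source may report more compounds than this note shows. Statements on the series, on what has been measured and on what is new or still open speak of the compounds shown alone.

Compound 2, `O=S(=O)(Nc1ncccn1)c1ccc2c(c1)OCC[C@@H]2c1ccc(C(F)(F)F)cc1-c1ccc(F)nc1`: 2.8
Compound 3, `Cn1nccc1-c1cc(C(F)(F)F)ccc1[C@H]1CCOc2cc(S(=O)(=O)Nc3nccs3)ccc21`: 2.2
Compound 1, `O=S(=O)(Nc1nccs1)c1ccc2c(c1)OCC[C@H]2c1ccc(C(F)(F)F)cc1-c1ccc(F)nc1`: "not determined" (no result reported)

Three compounds of this series were characterised, and for compound 1 no result is recorded in a physicochemical assay for lipophilicity; a higher number here means a more lipophilic compound, a lower number a more polar compound. In this assay compound 2 gives 2.8, and compound 3 gives 2.2. Compound 3 therefore stands at the lower of the two numbers, with compound 2 the nearest neighbour at a distance that lies beyond the scatter of repeated measurements.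

The next compound, compound 4, `O=S(=O)(Nc1nccs1)c1ccc2c(c1)OCC[C@@H]2c1ccc(C(F)(F)F)cc1-c1ccc(F)nc1`, is derived from compound 3 by a single exchange: 6-fluoropyridin-3-yl in place of 1-methyl-1H-pyrazol-5-yl on an aromatic carbon. The rest of the shared core, including the sulfonamide and the thiazole, is untouched.

Within the data shown here, no directly comparable pair of measured compounds isolates this exchange, so the size of the step has to be estimated. Since compound 2, which carries the same 6-fluoropyridin-3-yl group, gives 2.8, compound 4 is expected to move upward from compound 3 by a step of a number 0.90 log units higher from compound 3 to compound 4 (beyond the scatter), a step larger than the scatter. Compound 4 is thus estimated at 3.1 in this assay, with a likely range from 2.6 to 3.6.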

Compound 4, distribution coefficient: 3.2
For compound 4 the middle estimate is 0.10 log units below the measured one, and the stated range covers the measured number.
By their numbers in this assay, from the lowest: compound 3; then compound 2; then compound 4.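

Compound 4 links compound 2 and compound 3, which differ in two places, so their gap could not show how much belonged to either exchange. In this assay, the exchange of 1-methyl-1H-pyrazol-5-yl for 6-fluoropyridin-3-yl on an aromatic carbon can now be read alone, and it gives a number 1.00 log units higher from compound 3 to compound 4 (beyond the scatter). With the 6-fluoropyridin-3-yl group held fixed, the exchange of pyrimidin-2-yl for 1,3-thiazol-2-yl on a sulfonamide nitrogen gives a number 0.40 log units higher from compound 2 to compound 4 (beyond the scatter), so the change on the aromatic carbon is the larger of the two, although each rests on a single pair.

The compounds shown leave open how a pyridin-3-yl group without the fluorine, a plain phenyl ring or a morpholine on the same aromatic carbon would compare with the two groups seen there. The role of the configuration also stays unresolved, as compound 1 has no number in this assay to set against compound 4, and the pair is defined by this: the fact that compounds 1 and 4 differ only in the configuration as drawn.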